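The source may report more compounds than this note shows. Statements on the series, on what has been measured and on what is new or still open speak of the compounds shown alone.

Measured so far in a functional assay on a cell-free system (plasma, Homo sapiens), with a stated time of 3 min; on this read-out higher numbers stand for weaker inhibition and lower numbers for stronger inhibition:
- compound 1, `CC(C)(C)[C@@H](O)C(=O)N1CSC[C@H]1C(=O)NCc1cc(Cl)ccc1-n1cnnn1`, gives 1200 nM
- compound 2, `COC(C)(C)[C@@H](O)C(=O)N1[C@H](C(=O)NCc2cc(Cl)ccc2-n2cnnn2)C[C@@H]2C[C@@H]21`, gives 1000 nM
- compound 3, `O=C(NCc1cc(Cl)ccc1-n1cnnn1)[C@@H]1[C@H]2C[C@H]2CN1C(=O)[C@H](O)Cc1ccccc1`, gives 1200 nM

All three compounds share a core that ends in the same chlorinated benzylamide carrying a tetrazole, and they differ in the group that sits on the hydroxylated carbon next to the carbonyl at the other end. Compound 2 has the lowest of the three numbers, but its gaps to compound 1 and to compound 3 are both within the usual scatter of this assay, so the three compounds cannot be told apart on these values.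

Compound 4, `O=C(NCc1cc(Cl)ccc1-n1cnnn1)[C@@H]1C[C@@H]2C[C@@H]2N1C(=O)[C@H](O)c1ccccc1`, has not yet been measured. Compared with compound 2, the change is phenyl in place of 1-methoxy-1-methylethyl on a saturated chain carbon bound to a carbonyl carbon and an oxygen on a saturated carbon. For the measured compounds named here, no step between two measured compounds isolates this particular exchange, so there is no direct precedent to lean on. What the measured set does show is that three rather different groups at this position all give numbers in the same narrow band, which suggests this position tolerates variation without large swings in this assay. The step from compound 2 to compound 4 is therefore expected to be small, a 1.4-fold higher number from compound 2 to compound 4 (0.15 log units; within the scatter), in either direction or none beyond the scatter. Compound 4 is estimated at 1400 nM, with a range from 500 nM to 4000 nM.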

Compound 4, half-maximal inhibitory concentration: 620 nM
The estimate for compound 4 lay 2.3-fold (0.35 log units) above the measured number; measured number inside the range.
By their numbers in this assay, from the lowest: compounds 4, 2, 1 and 3 (each within the scatter of the next).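

For the compounds shown here, this is the first comparison in the set that changes only one place. In this assay, putting phenyl in place of 1-methoxy-1-methylethyl on the saturated chain carbon gives a 1.6-fold lower number from compound 2 to compound 4 (0.21 log units; within the scatter), so compound 2 and compound 4 cannot be told apart. The exchange replaces an open, branched group carrying a hydrogen-bond acceptor with an all-carbon aromatic ring that has none, and neither the loss of that acceptor nor the arrival of the ring moves the number beyond the scatter, at least on this shared core. Nothing available here explains why this exchange is tolerated.

This single pair leaves open whether the tolerance extends to groups that differ more sharply from these two, such as an amine or a carboxylic acid at the same carbon. It also leaves open whether a phenyl bearing a chlorine or a methoxy group, or a pyridine ring in place of the phenyl, would stay within the scatter of compound 4 or produce a clear step.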